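The source may report more compounds than this note shows. Statements on the series, on what has been measured and on what is new or still open speak of the compounds shown alone.

Measured so far:
Compound 1 `CC(=O)OC1C(CBr)OC(n2c(Cl)nc3cc(Cl)c(Cl)cc32)C1OC(C)=O`: 60000 nM
Compound 2 `CC(=O)OC1C(CN=[N+]=[N-])OC(n2c(Cl)nc3cc(Cl)c(Cl)cc32)C1OC(C)=O`: 70000 nM
Compound 3 `O[C@@H]1[C@@H](CBr)OC(n2c(Cl)nc3cc(Cl)c(Cl)cc32)[C@@H]1O`: 90000 nM

All three numbers come from a functional assay on KB cells (Homo sapiens) for inhibition (a higher number here means a weaker inhibitor, a lower number a stronger inhibitor), and all lie within the scatter of one another, so no order among compounds 1, 2 and 3 can be read from them.

The change from compound 1 to compound 2 is azido in place of bromo on a saturated chain carbon bound to a saturated ring carbon. Its effect was a 1.2-fold higher number from compound 1 to compound 2 (0.07 log units; within the scatter), which is no real movement.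

Compound 3 carries the same bromomethyl as compound 1 on a different core; the difference between the two cores is not broken down here.

Compound 4 `[N-]=[N+]=NC[C@H]1OC(n2c(Cl)nc3cc(Cl)c(Cl)cc32)[C@H](O)[C@@H]1O` has not yet been measured. Relative to compound 3 it shows (azido in place of bromo on a saturated chain carbon bound to a saturated ring carbon), the same change as from compound 1 to compound 2, at the same place. Among the compounds with values here, with only that one precedent, and that precedent flat, the expectation for compound 4 is a step of a 1.2-fold higher number from compound 3 to compound 4 (0.07 log units; within the scatter), resting on a 1.2-fold higher number from compound 1 to compound 2 (0.07 log units; within the scatter). In this assay compound 4 is therefore estimated at 105000 nM, with a plausible range from 45000 nM to 250000 nM.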

Compound 4, half-maximal inhibitory concentration: 70000 nM
Compound 4: the middle estimate sits 1.5-fold (0.18 log units) above what was measured, and the stated range covers the measured number.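

In this assay, azido in place of bromo on the core of the second pair gives a 1.3-fold lower number from compound 3 to compound 4 (0.11 log units; within the scatter), which is no real movement. Set beside the earlier step, the change carries from one core to the other with no detectable difference: the same change on two cores in this assay, a 1.2-fold higher number (0.07 log units; within the scatter) from compound 1 to compound 2 and a 1.3-fold lower number (0.11 log units; within the scatter) from compound 3 to compound 4, 1.5-fold (0.18 log units) apart, within the scatter of two such steps. This shows that bromomethyl to azidomethyl stays flat on both cores shown; it does not show that the two groups are interchangeable on other cores or in other assays, and two flat steps cannot say what sets the level of these numbers.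

Going by these compounds, only bromo and azido appear on this saturated chain carbon, so it stays open whether an amine, a carboxylic acid or a longer chain at that place would move the number beyond the scatter. Also open, on these data alone, is whether any change to the shared core would give a clearly lower number in this assay.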